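Adding one more chain carbon to the ester

The source may report more compounds than this note shows. Statements on the series, on what has been measured and on what is new or still open speak of the compounds shown alone.

Compound 2 `CCCCCCCCCCOC(=O)C(CCCCN1C(=O)CCC1=O)N1CCCCC1=O` was examined in an ADME assay on SK-N-MC cells (Homo sapiens) for antiproliferative activity, read by MTT assay, with a stated time of 72 h; a higher number here means a weaker inhibitor, a lower number a stronger inhibitor. In this assay compound 2 gives only the limit > 6250 nM, not a number. Compound 1 `CCCCCCCCCOC(=O)C(CCCCN1C(=O)CCC1=O)N1CCCCC1=O` likewise gives only the limit > 6250 nM. The step that the two limits leave unreadable from compound 1 to compound 2 is therefore unreadable in size. Compound 3 `CCCCCCCCCCCOC(=O)C(CCCCN1C(=O)CCC1=O)N1CCCCC1=O` differs from compound 2 by methyl in place of hydrogen on a saturated chain carbon, ten or more bonds along the chain from an oxygen next to a carbonyl group. Going by the values given here, the single measured step bears on this change but yields no size, and both values shown sit at the limit of > 6250 nM in this assay, at which 2 of the 2 values shown sit. No step beyond the scatter is expected from compound 2 to compound 3. Compound 3 is therefore estimated at 12000 nM, within 5000 nM to 30000 nM. That expectation corresponds to the step that the limit leaves unreadable from compound 2 to compound 3.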

Compound 3, half-maximal inhibitory concentration: > 6250 nM
Compound 3 ended at the assay's limit (the forecaster's own chance of this, stated with the estimate: 85%); the middle value does not contradict the limit.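

Going by these compounds alone, with compound 3 also giving only a limit in this assay, no step among compound 1, compound 2 and compound 3 can be read. The compounds shown leave open how strongly any of them acts, and whether a longer ester chain changes that at all.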